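Swapping the group on the aromatic ether chain

The compounds below may be only part of what the source reports. "The series", "measured", "known", "first", "only" and "open" are said of these compounds alone.

Measured so far in a functional assay on aorta (Rattus norvegicus, strain Sprague-Dawley) for inhibition; a higher number here means that more compound is needed for the effect, a lower number that less compound is needed:
- compound 1 `COc1cc2c(c3c1C[C@@H]1[C@@H](C)CO[C@]1(C)O3)C[C@@H]1[C@@H](C)CO[C@]1(C)O2` gives 17000 nM
- compound 2 `C=C=CCOc1cc2c(c3c1C[C@@H]1[C@@H](C)CO[C@]1(C)O3)C[C@@H]1[C@@H](C)CO[C@]1(C)O2` gives 12000 nM

Compound 2 stands level with compound 1, the two values lying within the scatter of each other. Compound 3 `C[C@H]1CO[C@]2(C)Oc3cc(OC/C=C/c4ccccc4)c4c(c3C[C@H]12)O[C@@]1(C)OC[C@H](C)[C@H]1C4` differs from compound 2 by 2-phenylethenyl in place of propa-1,2-dien-1-yl on a saturated chain carbon bound to an oxygen on an aromatic ring and carries 2-phenylethenyl in place of propa-1,2-dien-1-yl on a saturated chain carbon bound to an oxygen on an aromatic ring. Going by the values given here, only one measured step bears on this change: a 1.4-fold lower number from compound 1 to compound 2 (0.15 log units; within the scatter) for propa-1,2-dien-1-yl in place of hydrogen at the same place. Among the compounds with values here, no measured compound carries 2-phenylethenyl, so this guide is weak. With that small step alone, no change beyond the scatter is expected in this assay and no direction is favoured. The estimated step is a 1.2-fold lower number from compound 2 to compound 3 (0.08 log units; within the scatter) at the middle of a wide range. For compound 3 the expected value is 10000 nM with an estimated range from 3500 nM to 30000 nM for now.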

Compound 3, half-maximal effective concentration: 64000 nM
Estimate against measurement, compound 3: 6.4-fold (0.81 log units) below; measured number outside the range, above it.
By their numbers in this assay, from the lowest: compounds 2 and 1 (each within the scatter of the next); then compound 3.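

In this assay the group on a saturated chain carbon bound to an oxygen on an aromatic ring can move the number beyond the scatter, which the earlier step did not show. 2-Phenylethenyl in place of propa-1,2-dien-1-yl gives a 5.3-fold higher number from compound 2 to compound 3 (0.73 log units; beyond the scatter) and 2-phenylethenyl in place of hydrogen gives a 3.8-fold higher number from compound 1 to compound 3 (0.58 log units; beyond the scatter) in the same direction, so in these three compounds the group with the six-membered aromatic ring needs more compound for the effect. No measurement at hand accounts for this rise.

Three compounds cannot separate the contribution of the aromatic ring from that of the 8 heavy atoms in 2-phenylethenyl. Going by these compounds, whether an amine or a carboxylic acid at this place would lower the number or raise it remains open.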